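A few compounds are considered here, and "the series" means these few. Any claim that something is new, unique, unknown or untested is made for them only; others in the source may bear on it.

Working notes on the series.

Three compounds share one core and have numbers in a functional assay on PC-3 cells (Homo sapiens) for antiproliferative activity, read by MTT assay, with a stated time of 72 h; a higher number here means a weaker inhibitor, a lower number a stronger inhibitor. Compound 1 `CCC/C=C/C(=O)Nc1cc2c(N3CCc4ccccc43)ncnc2cc1OC` gives 4240 nM. Compound 2 `CCC/C=C/C(=O)Nc1cc2c(N3CCCc4ccccc43)ncnc2cc1OC` gives 2240 nM, and compound 3 `CCC/C=C/C(=O)Nc1cc2c(N3CCCc4ccccc43)ncnc2cc1O[C@@H]1CCOC1` gives 11800 nM. Compound 2 carries the lowest of the three numbers; the gap to compound 1, a 1.9-fold lower number from compound 1 to compound 2 (0.28 log units; within the scatter), is within the scatter, so no order between compound 1 and compound 2 is claimed, while the gap to compound 3, a 5.3-fold higher number from compound 2 to compound 3 (0.72 log units; beyond the scatter), is beyond it.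

Compound 4 `COc1cc2ncnc(N3CCCc4ccccc43)c2cc1NC(=O)/C=C/CN1CCCC1` is not yet measured. Relative to compound 2 the difference is pyrrolidin-1-yl in place of ethyl on a saturated chain carbon bound to a double-bonded chain carbon. Neither measured step touches this part of the molecule: the step from compound 1 to compound 2 concerns the amine on the aromatic carbon, and the step from compound 2 to compound 3 concerns the group on the ring oxygen. Among the compounds with values here, no measured step therefore bears on the change to compound 4, and the expectation rests only on the value of compound 2, 2240 nM, with a wide range.

For compound 4 the estimated number in this assay is 1500 nM, between 400 nM and 6000 nM, an expected step of a 1.5-fold lower number from compound 2 to compound 4 (0.17 log units; within the scatter).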

Compound 4, half-maximal inhibitory concentration: 1740 nM
For compound 4 the middle estimate is 1.2-fold (0.06 log units) below the measured one, within the range that was stated.
By their numbers in this assay, from the lowest: compounds 4, 2 and 1 (each within the scatter of the next, the first and the last beyond it); then compound 3.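

Within the data shown here, the swap of ethyl for pyrrolidin-1-yl, on a saturated chain carbon bound to a double-bonded chain carbon, is the first measured change at this end of the molecule, and in this assay it reads as a 1.3-fold lower number from compound 2 to compound 4 (0.11 log units; within the scatter), so the two compounds are not told apart. This position therefore accepts a five-membered non-aromatic ring carrying a nitrogen in place of ethyl, with no separable difference in this assay. Nothing available bears on why the number stays within the scatter.

The compounds shown leave open whether another group at this position, such as morpholin-4-yl, an open-chain dimethylamino or a carboxylic acid, would give a number beyond the scatter. They also leave open whether pyrrolidin-1-yl behaves alike with oxolan-3-yl on the ring oxygen.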